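The compounds below may be only part of what the source reports. "The series", "measured", "known", "first", "only" and "open" are said of these compounds alone.

Three compounds have been measured in a functional assay on CHO cells for agonist activity at Free fatty acid receptor 1 (Homo sapiens), read by FLIPR and calcium flux; on this read-out higher numbers stand for an effect only at larger amounts of compound and lower numbers for an effect already at smaller amounts:

compound 1 `O=C(O)COc1ccc(NCc2cccc(-c3ccccc3)c2)cc1F` gives 58.5 nM;
compound 2 `Cc1ccccc1-c1cccc(CNc2ccc(OCC(=O)O)c(F)c2)c1` gives 4.8 nM;
compound 3 `Cc1cc(O)ccc1-c1cccc(CNc2ccc(OCC(=O)O)c(F)c2)c1` gives 69.6 nM.

Compound 3 carries the highest of the three numbers. Its gap to compound 1 lies within the scatter, so these two cannot be separated: a 1.2-fold higher number from compound 1 to compound 3 (0.08 log units; within the scatter). Its gap to compound 2 is a different matter: a 15-fold higher number from compound 2 to compound 3 (1.16 log units; beyond the scatter). For comparison, the methyl step was also large: a 12-fold lower number from compound 1 to compound 2 (1.09 log units; beyond the scatter).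

Compound 4 `Cc1cc(OCCO)ccc1-c1cccc(CNc2ccc(OCC(=O)O)c(F)c2)c1` differs from compound 3 by a single change: 2-hydroxyethyl in place of hydrogen on an oxygen on an aromatic ring. For the measured compounds named here, no measured step touches this oxygen, so none bears directly on it. The two large steps concern the methyl group and the hydroxy group itself, and the step from compound 1 to compound 3 stayed within the scatter; they give no direction for lengthening hydroxy to 2-hydroxyethoxy. The expected step is therefore one within the scatter, a 1.2-fold lower number from compound 3 to compound 4 (0.06 log units; within the scatter), with a wide range either way. Compound 4 is estimated to give 60 nM, between 15 nM and 250 nM.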

Compound 4, half-maximal effective concentration: 36.1 nM
Compound 4: middle estimate off by 1.7-fold (0.22 log units), on the high side, and the stated range covers the measured number.
By their numbers in this assay, from the lowest: compound 2; then compounds 4, 1 and 3 (each within the scatter of the next).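

In this assay, putting 2-hydroxyethyl on the oxygen on an aromatic ring gives a step that cannot be told from scatter, a 1.9-fold lower number from compound 3 to compound 4 (0.29 log units; within the scatter), so this oxygen can carry that group without a separable change in the number. Measured against compound 2, however, the gap remains beyond the scatter, a 7.5-fold higher number from compound 2 to compound 4 (0.88 log units; beyond the scatter), so for compounds 3 and 4 alike, a hydroxy or a 2-hydroxyethoxy group on this aromatic carbon goes with a higher number than hydrogen, the hydroxy step being a 15-fold higher number from compound 2 to compound 3 (1.16 log units; beyond the scatter). Nothing given here accounts for these numbers.

The compounds shown leave open whether a methoxy group, a longer chain or an amine in place of the 2-hydroxyethyl on this oxygen would move the number beyond the scatter. They also leave open whether any group there could match compound 2, which gives 4.8 nM.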